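Swapping 3-chlorophenyl for 4-iodophenyl on a shared core

The compounds below may be only part of what the source reports. "The series", "measured", "known", "first", "only" and "open" are said of these compounds alone.

- compound 1 `Oc1ccc2ccccc2c1C(Nc1nc2ccc(Cl)cc2s1)c1cn(-c2ccccc2)nc1-c1ccc(Cl)cc1`: 27500 nM
- compound 2 `Oc1ccc2ccccc2c1C(Nc1nc2ccc(Cl)cc2s1)c1cn(-c2ccccc2)nc1-c1cccc(Cl)c1`: 17500 nM
- compound 3 `Oc1ccc2ccccc2c1C(Nc1nc2ccc(Cl)cc2s1)c1cn(-c2ccccc2)nc1-c1ccc(I)cc1`: not yet measured

For the measured compounds named here, in a functional assay on MCF7 cells (Homo sapiens) for antiproliferative activity, read by MTT assay, with a stated time of 48 h (on this read-out lower numbers stand for stronger inhibition and higher numbers for weaker inhibition), compound 2 gives 17500 nM, a value that cannot be told apart from that of compound 1, as the only measured step shows: a 1.6-fold lower number from compound 1 to compound 2 (0.20 log units; within the scatter). The next change is 4-iodophenyl in place of 3-chlorophenyl on an aromatic carbon, and the count is this: 4-iodophenyl in place of 3-chlorophenyl on an aromatic carbon. The measured step bears on it. That step swaps the aryl group at the same place, yet it stayed small at a 1.6-fold lower number from compound 1 to compound 2 (0.20 log units; within the scatter). Going by the values given here, no measured compound carries iodine, so this guide is thin, and no shift beyond the scatter is foreseen in this assay. The expected size of the change is a 1.1-fold higher number from compound 2 to compound 3 (0.06 log units; within the scatter). For compound 3 the estimated value is 20000 nM, with an expected range from 8000 nM to 50000 nM.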

Compound 3, half-maximal inhibitory concentration: 65000 nM
For compound 3 the middle estimate is 3.3-fold (0.51 log units) below the measured one; measured number outside the range, above it.
By their numbers in this assay, from the lowest: compounds 2 and 1 (each within the scatter of the next); then compound 3.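

In this assay, this position proves sensitive to the aryl group it carries: 4-iodophenyl in place of 3-chlorophenyl gives a 3.7-fold higher number from compound 2 to compound 3 (0.57 log units; beyond the scatter), a step that lies beyond the scatter, unlike the earlier step between the two chlorophenyl compounds. Iodo in place of chloro alone gives a 2.4-fold higher number from compound 1 to compound 3 (0.37 log units; beyond the scatter), so the kind of halogen on this aryl group matters here, and both new steps point to weaker inhibition. The data shown offer no measured explanation for this loss.

From the compounds shown here alone, whether fluoro, methoxy or an amine on this aryl group would stay close to compound 2 or weaken inhibition further remains open. So does the outcome for 3-iodophenyl, which would show whether iodine behaves differently when the aryl group carries it elsewhere.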